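The source may hold more compounds than are shown below. What is called first, only, known or untested is meant among the compounds shown, and "the series" means these compounds.

Compound 1 `CCC1(CCCCN2CCN(c3cccc(Cl)c3)CC2)C(=O)Nc2ccccc21`: 0.41 nM
Compound 2 `CCC1(CCCCCN2CCN(c3cccc(Cl)c3)CC2)C(=O)Nc2ccccc21`: 1.45 nM

In an assay on CHO cells for displacement of a labelled ligand from 5-hydroxytryptamine receptor 7 (Homo sapiens) (a lower number here means a stronger inhibitor, a higher number a weaker inhibitor), compound 1 gives 0.41 nM, the lower of the two numbers, while compound 2 gives 1.45 nM, a higher number that lies beyond the usual scatter. Compound 3 `CCC1(CCCCN2CCN(c3ccccc3OC)CC2)C(=O)Nc2ccccc21` has not been measured. It differs from compound 1 in one place: 2-methoxyphenyl in place of 3-chlorophenyl on an amine nitrogen in a ring. For the measured compounds named here, no measured pair shows what such a change does here. In this assay the step expected is a 2.4-fold higher number from compound 1 to compound 3 (0.39 log units; beyond the scatter), a small rise close to the scatter. For compound 3 the estimate is 1 nM, with a range from 0.2 nM to 5 nM.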

Compound 3, inhibition constant: 5.38 nM
Beside the measured number, compound 3's estimate is 5.4-fold (0.73 log units) below it, outside the stated range (above it).
By their numbers in this assay, from the lowest: compound 1; then compound 2; then compound 3.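

In this assay, putting 2-methoxyphenyl in place of 3-chlorophenyl on the ring amine nitrogen gives a 13-fold higher number from compound 1 to compound 3 (1.12 log units; beyond the scatter), a large step well beyond the scatter. So the group on this nitrogen strongly affects the number, and this swap moves it the wrong way for a stronger inhibitor. No supporting data explain the rise. The compounds shown leave open whether losing the chlorine or gaining the methoxy group matters more. They also leave open how an unsubstituted phenyl or a pyridine ring would behave on this nitrogen.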